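The compounds below may be only part of what the source reports. "The series", "measured", "known", "first", "only" and "open" are said of these compounds alone.

Measured in a functional assay on MCF7 cells (Homo sapiens) for antiproliferative activity, read by MTT assay, with a stated time of 72 h; on this read-out higher numbers stand for weaker inhibition and lower numbers for stronger inhibition:
compound 1 `O=C(COc1ccc(C(=O)/C=C/c2cccc(Br)c2)cc1)N[C@H]1CCOC1=O` gives 28300 nM
compound 2 `O=C(CNc1ccccc1)N[C@H]1CCOC1=O` gives > 64000 nM, which is a limit of the assay and not a number
compound 3 `O=C(COc1ccc(C(=O)/C=C/c2ccccc2)cc1)N[C@H]1CCOC1=O` gives > 64000 nM, also a limit of the assay and not a number

Compound 3 and compound 1 share one core and differ only by bromo in place of hydrogen on an aromatic carbon. That change produced an at least 2.2-fold lower number from compound 3 to compound 1 (0.35 log units; beyond the scatter); its size is known only as a bound because of the limit of > 64000 nM in this assay, at which 2 of the 3 values shown sit. The difference between the core of compound 2 and the core of compound 3 is not broken down here. Compound 4 `O=C(CNc1ccc(Br)cc1)N[C@H]1CCOC1=O` has not yet been measured; it differs from compound 2 by bromo in place of hydrogen on an aromatic carbon. This is the same kind of change as before, though here the bromo sits para to a large group rather than meta to a large group. Beside an at least 2.2-fold lower number from compound 3 to compound 1 (0.35 log units; beyond the scatter), the step expected is an at least 1.0-fold lower number from compound 2 to compound 4 (0.02 log units; that floor lies within the scatter), resting on that earlier step while allowing for the different core of compound 2. Compound 4 is therefore expected to give 60000 nM in this assay, and the result may again be only a limit.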

Compound 4, half-maximal inhibitory concentration: > 64000 nM
Compound 4 was reported as a limit; the forecaster's own chance of this, stated with the estimate: 55%; middle value at least 1.0-fold (0.02 log units) away from the limit.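

Compound 2 and compound 4 both sit at a limit of the assay, so no size can be read for this step: the limit of > 64000 nM in this assay, at which 3 of the 4 values shown sit. Going by these compounds, whether bromo in place of hydrogen lowers the number on the core of compound 2, as it did on the core of compound 3, stays open.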